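A few compounds are considered here, and "the series" means these few. Any claim that something is new, unique, unknown or untested is made for them only; others in the source may bear on it.

Measured compounds:
- compound 1, `Cc1nnsc1CO/N=C/c1c(C)nn(C)c1Oc1ccc(Br)cc1`: 12800 nM
- compound 2, `Cc1nnsc1CO/N=C/c1c(C)nn(C)c1Oc1ccc(I)cc1`: > 50000 nM
- compound 3, `Cc1nnsc1CO/N=C/c1c(C)nn(C)c1Oc1ccc(OC(F)(F)F)cc1`: > 50000 nM

In a functional assay on PANC-1 cells (Homo sapiens) for inhibition, read by MTT assay, with a stated time of 48 h (a higher number here means a weaker inhibitor, a lower number a stronger inhibitor), compound 1 gives 12800 nM. For compound 2 the value > 50000 nM is a limit of the assay, not a number. For compound 3 the value > 50000 nM is likewise a limit, not a number. The three compounds share one core and differ only in the group on the aryl ether ring: an at least 3.9-fold higher number from compound 1 to compound 2 (0.59 log units; beyond the scatter), and an at least 3.9-fold higher number from compound 1 to compound 3 (0.59 log units; beyond the scatter). Between compound 2 and compound 3 the step is a step that the two limits leave unreadable from compound 2 to compound 3. Compound 3 thus stands at the weak end of what is shown, at the limit of > 50000 nM in this assay, at which 2 of the 3 values shown sit.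

Compound 4, `CCc1nnsc1CO/N=C/c1c(C)nn(C)c1Oc1ccc(OC(F)(F)F)cc1`, differs from compound 3 by methyl in place of hydrogen on a saturated chain carbon bound to an aromatic carbon. Within the data shown here, none of the measured steps touches this part of the molecule; all of them change the group on the aryl ether ring, so no measured step bears directly on this change. The starting point is a limit, and a small change elsewhere gives no ground to expect a move out of it. Compound 4 is therefore expected to give 60000 nM in this assay, within 20000 nM to 200000 nM. The step that the limit leaves unreadable from compound 3 to compound 4 is expected to stay within the scatter, most likely again as a limit rather than a number.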

Compound 4, half-maximal inhibitory concentration: > 50000 nM
Compound 4 ended at the assay's limit; the forecaster's own chance of this, stated with the estimate: 75%; the middle value does not contradict the limit.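

In this assay compound 4 gives > 50000 nM, which is a limit of the assay and not a number. Compound 3 also stands at a limit, so no step can be read between compound 3 and compound 4. The compounds shown leave open whether methyl to ethyl changes the value when the starting compound gives a readable number, as compound 1 does.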